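Carbonyl substituent step from compound 3 to compound 4

The source may hold more compounds than are shown below. What is called first, only, known or untested is meant among the compounds shown, and "the series" means these compounds.

Measured so far in an ADME assay (Rattus norvegicus, strain Wistar Han) for pharmacokinetics (on this read-out lower numbers stand for narrower distribution and higher numbers for wider distribution into tissues), for this series
- compound 1 `CCn1c(-c2cnc(C)nc2)nc2c(N[C@H]3CCN(C(=O)N4CC(OC)C4)C3)ncnc21` gives 0.7 L/kg
- compound 2 `CCn1c(-c2cnc(C)nc2)nc2c(O[C@H]3CCN(C(=O)C4CC4)C3)ncnc21` gives 0.7 L/kg
- compound 3 `CCn1c(-c2cnc(C)nc2)nc2c(N[C@H]3CCN(C(=O)C4CC(F)(F)C4)C3)ncnc21` gives 0.9 L/kg

Compound 3 stands at 0.9 L/kg and the three measured compounds all lie within the scatter of one another. Compound 4 `CCn1c(-c2cnc(C)nc2)nc2c(N[C@H]3CCN(C(=O)C4CC4)C3)ncnc21` is still unmeasured. The structural change is cyclopropyl in place of 3,3-difluorocyclobutyl on a carbonyl carbon.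

Among the compounds with values here, only one measured step touches this place. It is a 1.3-fold higher number from compound 1 to compound 3 (0.11 log units; within the scatter), which stays within the scatter and involves 3-methoxyazetidin-1-yl rather than cyclopropyl. Within the data shown here, compound 2 also carries cyclopropyl on a carbonyl carbon and gives 0.7 L/kg, but no single-place step ties it to compound 3. The direct exchange of these two groups has not been measured, so the evidence is thin, and no direction can be argued from it.

No step beyond the scatter is therefore expected in this assay. The expected step is a 1.1-fold lower number from compound 3 to compound 4 (0.05 log units; within the scatter), well inside the scatter. Compound 4 is estimated at 0.8 L/kg with 0.5 L/kg to 1.3 L/kg as the expected range.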

Compound 4, volume of distribution: 1 L/kg
Compound 4: middle estimate off by 1.3-fold (0.10 log units), on the low side, within the range that was stated.
By their numbers in this assay, from the lowest: compounds 1, 2, 3 and 4 (each within the scatter of the next).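

The direct exchange in this assay gives a 1.1-fold higher number from compound 3 to compound 4 (0.05 log units; within the scatter) and so settles what compound 3 alone could not: cyclopropyl and 3,3-difluorocyclobutyl on a carbonyl carbon cannot be told apart on this read-out, although the group that leaves has 6 heavy atoms and the group that enters has 3. The second new comparison, against the 3-methoxyazetidin-1-yl group, gives a 1.4-fold higher number from compound 1 to compound 4 (0.15 log units; within the scatter), so none of the three groups compared at this place separates from the others in this assay on the shared core. No supporting evidence bears on why the read-out stays flat at this place.

Still open, on these data alone, is whether any group on this carbonyl carbon can carry the number beyond the scatter, and a carboxylic acid or a primary amine at the end of a longer chain would put that to the test. Also open, as far as these compounds go, is whether the flat picture holds with the same three groups on a different core, since these comparisons all rest on a single one.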